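Adding a Second Chloro to the Core of Compound 1

The source may report more compounds than this note shows. Statements on the series, on what has been measured and on what is new or still open speak of the compounds shown alone.

The shared core of compound 1 `ClCc1cccc(Cn2cnc3ncnc(Cl)c32)c1` carries one chloro, and in a functional assay on OVCAR-8 cells (Homo sapiens) for cytotoxicity, read by sulforhodamine B assay, with a stated time of 48 h (on this read-out lower numbers stand for higher toxicity in this test and higher numbers for lower toxicity in this test), compound 1 gives 60300 nM. Among the three measured compounds this is the second highest number. Compound 3 `ClCc1ccc(Cn2cnc3c(Cl)nc(Cl)nc32)cc1` gives 72400 nM, which lies within the usual scatter of compound 1, while compound 2 `ClCc1ccc(Cn2cnc3nc(Cl)nc(Cl)c32)cc1` gives 8310 nM, a clearly lower number, so compound 2 is the more toxic of that pair in this assay. Compound 4 `ClCc1cccc(Cn2cnc3nc(Cl)nc(Cl)c32)c1` differs from compound 1 by chloro in place of hydrogen on an aromatic carbon, between two ring nitrogen atoms and meta to a chloro group. Among the compounds with values here, no measured pair differs in exactly this way. Compound 2 also carries two chloro groups on its core and gives 8310 nM, which points toward a downward step beyond the scatter. The expected step is a 3.0-fold lower number from compound 1 to compound 4 (0.48 log units; beyond the scatter). Compound 4 is therefore estimated at 20000 nM, with a range from 6000 nM to 60000 nM.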

Compound 4, concentration lethal to 50% of the cells: 45700 nM
Estimate against measurement, compound 4: 2.3-fold (0.36 log units) below; the range from low to high includes it.
By their numbers in this assay, from the lowest: compound 2; then compounds 4, 1 and 3 (each within the scatter of the next).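

In this assay chloro in place of hydrogen on an aromatic carbon, between two ring nitrogen atoms, gives a 1.3-fold lower number from compound 1 to compound 4 (0.12 log units; within the scatter) and so leaves the read-out within the usual scatter at this position. Within the data shown here, the earlier compounds held no pair differing in this one place, so this is the only direct reading of the change. Nothing shown here offers an explanation for the result. As far as these compounds go, whether a different group at this position, such as an amine or a methoxy group, would shift the number remains open.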